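Replacing the cyclobutylmethyl ether of compound 1 with an aromatic ethyl ether

The source may hold more compounds than are shown below. What is called first, only, known or untested is meant among the compounds shown, and "the series" means these compounds.

Compound 1 `O=C(O)CCn1c(=O)oc2cc(OCC3CCC3)c(Cl)cc21` is the starting point of this step. In an assay on HEK293 cells for inhibition of kynurenine 3-monooxygenase (Homo sapiens), read by LC-MS, with a stated time of 20 h (on this read-out higher numbers stand for weaker inhibition and lower numbers for stronger inhibition), compound 1 gives 1260 nM, the highest of the three numbers measured. Among the measured compounds shown here, its nearest neighbour is compound 2 `CC(C)Cc1cc2oc(=O)n(CCC(=O)O)c2cc1Cl`, which gives 794 nM; the only single-point step measured, a 1.6-fold lower number from compound 1 to compound 2 (0.20 log units; within the scatter), lies within the scatter and so says nothing about direction. For the measured compounds named here, the furthest is compound 3 `Cc1ccc([C@@H](C)Oc2cc3onc(CCC(=O)O)c3cc2Cl)nn1`, which gives 3.16 nM, though compound 3 differs from compound 1 in its core as well as in the ether group, so no single step can be drawn from its value.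

Compound 4 `C[C@@H](Oc1cc2oc(=O)n(CCC(=O)O)c2cc1Cl)c1ncccn1` is the untested compound. a group of 8 heavy atoms (6 carbon, 2 nitrogen; one six-membered aromatic ring with 2 hetero atoms) in place of a group of 5 heavy atoms (5 carbon; one four-membered non-aromatic ring of carbon only), on an oxygen on an aromatic ring The entering group carries one six-membered aromatic ring with 2 hetero atoms and 1 defined stereocentre, on the same oxygen on an aromatic ring. Going by the values given here, no measured step isolates this change on the core of compound 1. The value of compound 3 shows that an ether of this kind, on a related core, can sit far below compound 1, so a large step downward is expected, a 42-fold lower number from compound 1 to compound 4 (1.62 log units; beyond the scatter), with wide uncertainty. Compound 4 is therefore estimated at 30 nM, between 5 nM and 200 nM.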

Compound 4, half-maximal inhibitory concentration: 3160 nM
Compound 4: middle estimate off by 110-fold (2.02 log units), on the low side; measured number outside the range, above it.
By their numbers in this assay, from the lowest: compound 3; then compounds 2 and 1 (each within the scatter of the next); then compound 4.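

In this assay, the exchange on the oxygen on an aromatic ring gives a 2.5-fold higher number from compound 1 to compound 4 (0.40 log units; beyond the scatter), so on the core of compound 1 the entering group, with its six-membered aromatic ring with 2 hetero atoms and 1 defined stereocentre, raises the number modestly rather than lowering it. Among the compounds shown here, this is the first step beyond the scatter at this position, and it shows that an ether of this kind does not by itself give a low number on this core, so the low value of compound 3, 3.16 nM, cannot be credited to its ether group alone. The compounds shown offer no evidence on why the number rises at this position.

Open remains how much of the value of compound 3 belongs to its core and how much to its ether group, since no pair shown separates the two. Also open, on these data alone, is how a plain phenyl ring or a simple methoxy group on the same oxygen would read on the core of compound 1, and whether the mirror-image form of the entering group would read as compound 4 does.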